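The source may hold more compounds than are shown below. What is called first, only, known or untested is meant among the compounds shown, and "the series" means these compounds.

Working notes on the series. Within the data shown here, in a functional assay on HEK293 cells for agonist activity at D(4) dopamine receptor (Homo sapiens), read by FLIPR (on this read-out lower numbers stand for an effect already at smaller amounts and higher numbers for an effect only at larger amounts of compound), compound 1 `Cc1cc(C(=O)NCN2CCC(c3cccc[n+]3[O-])CC2)ccc1F` gives 50 nM, the second highest of the three numbers measured so far. Compound 3 `Cc1ccc([N+](=O)[O-])cc1NC(=O)CN1CCC(c2cccc[n+]2[O-])CC1` gives 134 nM, a higher number than compound 1, and this gap lies beyond the scatter. Compound 2 `Cc1cccc(NC(=O)CN2CCC(c3cccc(O)c3)CC2)c1` gives 8 nM, lower than both others, again beyond the scatter. Compound 4 `O=C(NCN1CCC(c2cccc[n+]2[O-])CC1)c1cc(Cl)cc(Cl)c1` differs from compound 1 in one place: 3,5-dichlorophenyl in place of 4-fluoro-3-methylphenyl on a carbonyl carbon. Among the measured compounds shown here, no pair of measured compounds differs in exactly this way, so there is no measured step to lean on. The step of a 1.2-fold higher number from compound 1 to compound 4 (0.08 log units; within the scatter) is expected to be no larger than the scatter, in no settled direction. For compound 4 in this assay the estimate is 60 nM, within a range from 15 nM to 250 nM.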

Compound 4, half-maximal effective concentration: 45 nM
For compound 4 the middle estimate is 1.3-fold (0.12 log units) above the measured one, within the range that was stated.
By their numbers in this assay, from the lowest: compound 2; then compounds 4 and 1 (each within the scatter of the next); then compound 3.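

In this assay, among these compounds, 3,5-dichlorophenyl in place of 4-fluoro-3-methylphenyl on a carbonyl carbon gives a 1.1-fold lower number from compound 1 to compound 4 (0.05 log units; within the scatter) and is the first step read at this position. Here, two aromatic rings of carbon only with the same heavy-atom count but different substituents read alike, so this change leaves the number in place. No measurement at hand accounts for this. Open, as far as these compounds go, is whether a carboxylic acid or an amine on that carbonyl carbon, in place of the aromatic ring, would also leave the number in place.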